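A few compounds are considered here, and "the series" means these few. Any claim that something is new, unique, unknown or untested is made for them only; others in the source may bear on it.

Measured so far, in an assay on isolated protein for inhibition of ubiquitin carboxyl-terminal hydrolase 7 (Homo sapiens), with stated times of 30 min and 2 h; a lower number here means a stronger inhibitor, a higher number a weaker inhibitor:
compound 1 `Cn1nc2c(=O)n(CC3(O)CCN(Cc4ccc(-c5n[nH]c(=O)o5)cc4Cl)CC3)cnc2c1-c1ccc(CN)cc1` — 171 nM
compound 2 `Cn1cc(-c2ccc(CN3CCC(O)(Cn4cnc5c(-c6ccc(CN)cc6)n(C)nc5c4=O)CC3)c(Cl)c2)cn1` — 291 nM

Compound 2 holds the highest of the two numbers in this assay; its nearest neighbour is compound 1, and the step of a 1.7-fold higher number from compound 1 to compound 2 (0.23 log units; within the scatter) lies within the scatter, so the two cannot be ordered against each other.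

Compound 3 `Cn1nc2c(=O)n(CC3(O)CCN(Cc4ccc(-c5ncco5)cc4Cl)CC3)cnc2c1-c1ccc(CN)cc1` is not yet measured. It differs from compound 2 in one place: 1,3-oxazol-2-yl in place of 1-methyl-1H-pyrazol-4-yl on an aromatic carbon. Among the measured compounds shown here, the only measured step that bears on this is the earlier exchange of the five-membered ring at the same aromatic carbon, a 1.7-fold higher number from compound 1 to compound 2 (0.23 log units; within the scatter), which stayed within the scatter. For the measured compounds named here, no other pair speaks to this position, and a single step of that size gives no direction to lean on. The expectation for the ring swap into compound 3 in this assay is accordingly no shift beyond the scatter, and the expected step is a 1.1-fold lower number from compound 2 to compound 3 (0.05 log units; within the scatter). Compound 3 is therefore estimated at 260 nM, with a range from 100 nM to 650 nM.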

Compound 3, half-maximal inhibitory concentration: 1120 nM
For compound 3 the middle estimate is 4.3-fold (0.63 log units) below the measured one; measured number above the stated range.
By their numbers in this assay, from the lowest: compounds 1 and 2 (each within the scatter of the next); then compound 3.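

In this assay the aromatic carbon para to a large group and meta to a chloro group proves sensitive to which five-membered ring it carries: 1,3-oxazol-2-yl in place of 1-methyl-1H-pyrazol-4-yl gives a 3.8-fold higher number from compound 2 to compound 3 (0.59 log units; beyond the scatter) and, in place of the five-membered aromatic ring with 3 hetero atoms, gives a 6.5-fold higher number from compound 1 to compound 3 (0.82 log units; beyond the scatter) in this series, whereas the earlier exchange at this carbon, a 1.7-fold higher number from compound 1 to compound 2 (0.23 log units; within the scatter), could not be ordered. A five-membered aromatic ring at this carbon is therefore not enough in itself to keep the number low, and the counts do not separate the groups in the latest exchange: 1-methyl-1H-pyrazol-4-yl and 1,3-oxazol-2-yl each have 2 hetero atoms in the ring, 0 hydrogen-bond donors, 2 hydrogen-bond acceptors and no net charge. No measurement at hand accounts for this step.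

Open, going by these compounds, is whether a group of another kind on this carbon, such as a carboxylic acid or an aminomethyl group, would stay with compound 1 and compound 2 or move with compound 3. These three compounds also leave open whether the sensitivity holds on any core other than the shared one.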